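Exchanging the Aryl Amide Group: Compound 3 to Compound 4

The source may report more compounds than this note shows. Statements on the series, on what has been measured and on what is new or still open speak of the compounds shown alone.

Compound 1 `COc1ccc(C(=O)Nc2cccc(-c3oc4cc(-c5ccc(F)cc5)ccc4c(=O)c3O)c2)cc1` gives 16500 nM in a functional assay on MDA-MB-231 cells (Homo sapiens) for antiproliferative activity, read by CCK-8 assay, with a stated time of 72 h; a higher number here means a weaker inhibitor, a lower number a stronger inhibitor.
Compound 2 `O=C(Nc1cccc(-c2oc3cc(-c4ccc(F)cc4)ccc3c(=O)c2O)c1)c1ccc(C(F)(F)F)cc1` gives 29400 nM in this assay.
Compound 3 `O=C(Nc1cccc(-c2oc3cc(-c4ccc(F)cc4)ccc3c(=O)c2O)c1)c1ccc(Br)cc1` gives 24900 nM in this assay.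

Compound 3 sits close to both other compounds: a 1.5-fold higher number from compound 1 to compound 3 (0.18 log units; within the scatter) and a 1.2-fold lower number from compound 2 to compound 3 (0.07 log units; within the scatter). Compound 4 `O=C(Nc1cccc(-c2oc3cc(-c4ccc(F)cc4)ccc3c(=O)c2O)c1)c1cccc(F)c1` differs from compound 3 by 3-fluorophenyl in place of 4-bromophenyl on a carbonyl carbon. Going by the values given here, no measured step makes this exact change. The three measured steps, a 1.8-fold higher number from compound 1 to compound 2 (0.25 log units; within the scatter), a 1.5-fold higher number from compound 1 to compound 3 (0.18 log units; within the scatter) and a 1.2-fold lower number from compound 2 to compound 3 (0.07 log units; within the scatter), each swap one aryl substituent for another, and each stays within the scatter. On that basis the step of a 1.1-fold lower number from compound 3 to compound 4 (0.05 log units; within the scatter) is expected to stay within the scatter too, in no particular direction. Compound 4 is therefore estimated at 22000 nM in this assay, with a range from 9000 nM to 55000 nM.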

Compound 4, half-maximal inhibitory concentration: 2510 nM
For compound 4 the middle estimate is 8.8-fold (0.94 log units) above the measured one, and the stated range ends above it.
By their numbers in this assay, from the lowest: compound 4; then compounds 1, 3 and 2 (each within the scatter of the next).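

In this assay the aryl group on this carbonyl carbon proves able to shift the number, with a 9.9-fold lower number from compound 3 to compound 4 (1.00 log units; beyond the scatter) and a 12-fold lower number from compound 2 to compound 4 (1.07 log units; beyond the scatter) and a 6.6-fold lower number from compound 1 to compound 4 (0.82 log units; beyond the scatter) all beyond the scatter, while swaps among the earlier three stayed within it. Thus 3-fluorophenyl stands apart from all three 4-substituted phenyl groups shown. Nothing given here explains this difference.

This change alters both the halogen and its ring position, so the compounds shown cannot separate those two effects. Going by these compounds, whether 4-fluorophenyl, 3-bromophenyl or a phenyl carrying an amine would match compound 4 remains open.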